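The compounds below may be only part of what the source reports. "The series", "measured", "known", "first", "only" and "open" are said of these compounds alone.

Compound 1 `NS(=O)(=O)c1ccc(N2N=C(c3ccc(OCc4ccccc4)cc3)CC2c2ccc(Cl)cc2)cc1` and compound 2 `Cc1cccc(C2CC(c3ccc(OCc4ccccc4)cc3)=NN2c2ccc(S(N)(=O)=O)cc2)c1` share one core and were both tested in an ADME assay on Vero 76 cells (Chlorocebus sabaeus) for cytotoxicity, read by MTT assay, with a stated time of 96 h; on this read-out higher numbers stand for lower toxicity in this test and lower numbers for higher toxicity in this test. In this assay compound 1 gives 82000 nM, and compound 2 gives 100000 nM; the change a 1.2-fold higher number from compound 1 to compound 2 (0.09 log units; within the scatter), so on these two numbers compound 1 stands lowest, but only within the scatter of compound 2. Compound 3 `NS(=O)(=O)c1ccc(N2N=C(c3ccc(Oc4ccccc4)cc3)CC2c2ccc(Cl)cc2)cc1` is not yet measured. It differs from compound 1 by phenyl in place of benzyl on an oxygen on an aromatic ring. Among the compounds with values here, no measured step touches this position, so nothing here points in either direction, and the expected step of no change at the digits printed from compound 1 to compound 3 (within the scatter) is none beyond the scatter. Compound 3 is therefore estimated at 82000 nM, within 35000 nM to 150000 nM.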

Compound 3, half-maximal cytotoxic concentration: 88000 nM
Beside the measured number, compound 3's estimate is 1.1-fold (0.03 log units) below it; the measured number falls inside the stated range.
By their numbers in this assay, from the lowest: compounds 1, 3 and 2 (each within the scatter of the next).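

Within the data shown here, the first measured step at this position, benzyloxy to phenoxy, gives a 1.1-fold higher number from compound 1 to compound 3 (0.03 log units; within the scatter) in this assay. Exchanging benzyl for phenyl on this oxygen therefore leaves the cytotoxicity number within the scatter, so this test does not tell the two groups apart. Nothing available here explains this result.

Going by these compounds, both groups place a carbon-only aromatic ring on the oxygen, so it remains open whether an amine, a carboxylic acid or a longer alkyl chain there would move the number beyond the scatter.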